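A few compounds are considered here, and "the series" means these few. Any claim that something is new, unique, unknown or untested is made for them only; others in the source may bear on it.

Compound 2 `CCc1ccc(NC(=O)N[C@@H](C)c2ccccc2)cc1` stands at the top of the two numbers measured in an ADME assay on the whole organism with Oryza sativa as the target, tested at 1 uM (a higher number here means a weaker effect of the compound at the concentration tested, a lower number a stronger effect), where compound 2 gives 95%. Its nearest neighbour is compound 1 `CCc1ccc(NC(=O)N[C@H](C)c2ccccc2)cc1`, the same atoms and bonds drawn in the other configuration, and in this assay compound 1 gives 47%. For the measured compounds named here, the one measured step, a number 48 percentage points higher from compound 1 to compound 2 (beyond the scatter), is attributed to the fact that compounds 1 and 2 differ only in the configuration as drawn. Compound 3 `CC(C)c1ccc(NC(=O)N[C@@H](C)c2ccccc2)cc1` is not yet measured in this assay; it keeps the configuration of compound 2 and differs from it by methyl in place of hydrogen on a saturated chain carbon bound to an aromatic carbon and a saturated chain carbon. Going by the values given here, no measured step touches this kind of change: the only step seen swaps configuration and leaves every atom in place, so it says nothing about a methyl entering on the saturated chain carbon. With no guidance, the expectation is that the step of a number 5 percentage points lower from compound 2 to compound 3 (within the scatter) will stay within the scatter. Compound 3 is therefore estimated at 90% in this assay, with a likely range from 70% to 100%.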

Compound 3, a percentage reported as activity, at one concentration (the size of the read-out at that concentration, not a potency): 96%
Compound 3: middle estimate off by 6 percentage points, on the low side, within the range that was stated.
By their numbers in this assay, from the lowest: compound 1; then compounds 2 and 3 (each within the scatter of the next).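

In this assay, the step from ethyl to isopropyl, methyl in place of hydrogen on a saturated chain carbon bound to an aromatic carbon and a saturated chain carbon, reads a number 1 percentage points higher from compound 2 to compound 3 (within the scatter) and so lies within the scatter. For the compounds shown here, this is the first reading of a change in the atoms themselves, as the earlier step altered only the configuration as drawn. With the configuration of compound 2 kept, the entering methyl leaves the read-out at the end of the scale that stands for a weak effect at the concentration tested, and nothing available bears on why the step is this small.

Going by these compounds, whether the same methyl would read the same way in the configuration of compound 1 stays open, since this step was read only in the configuration of compound 2. Also open, on these data alone, is how a longer chain, an amine or a carboxylic acid would read on this saturated chain carbon, and whether any such group would bring the number in this assay away from the weak end of the scale.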